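Removing the Whole Chain from a Urea Inhibitor

The source may hold more compounds than are shown below. What is called first, only, known or untested is meant among the compounds shown, and "the series" means these compounds.

Two ureas built on a shared core have been measured. Compound 1 `CCCCCCCCCCCCCCc1ccc(NC(=O)Nc2c(C(C)C)cccc2C(C)C)cc1` carries a long chain on its second ring; in an assay on isolated protein for inhibition of acyl-CoA:cholesterol acyltransferase (Oryctolagus cuniculus) (a lower number here means a stronger inhibitor, a higher number a weaker inhibitor), compound 1 gives 500 nM. Compound 2 `CCCCCCCCc1ccc(NC(=O)Nc2c(C(C)C)cccc2C(C)C)cc1` keeps a shorter chain, and in this assay compound 2 gives 11 nM. Within the data shown here, that is the lowest of the two numbers, so compound 2 is the stronger of the pair; the only step measured so far is a 45-fold lower number from compound 1 to compound 2 (1.66 log units; beyond the scatter).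

Compound 3 `CC(C)c1cccc(C(C)C)c1NC(=O)Nc1ccccc1` goes one stage further: hydrogen in place of octyl on an aromatic carbon. Among the measured compounds shown here, the measured step shortened the chain and gave a lower number, but no measured step removes a chain altogether, so that step bears on this one only in part. Trimming part of a chain and taking a ring with no chain at all are different changes, and the direction cannot be read with confidence from one step. Compound 3 is therefore expected to give a higher number, with wide uncertainty, an estimated step of an 18-fold higher number from compound 2 to compound 3 (1.26 log units; beyond the scatter). Compound 3 is estimated at 200 nM, in the range 20 nM to 3000 nM.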

Compound 3, half-maximal inhibitory concentration: 910 nM
Compound 3: the middle estimate sits 4.6-fold (0.66 log units) below what was measured, within the range that was stated.
By their numbers in this assay, from the lowest: compound 2; then compounds 1 and 3 (each within the scatter of the next).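

In this assay, taking the octyl group off the ring altogether is a large loss, with an 83-fold higher number from compound 2 to compound 3 (1.92 log units; beyond the scatter), so the chain at this position is not simply a burden to be trimmed away. The earlier step pointed toward shorter being better, but that trend does not hold all the way down to hydrogen: compound 2, with its octyl chain, has a lower number than both the compound with the long chain and the compound with no chain, while compound 1 at 500 nM and compound 3 at 910 nM lie within the scatter of each other. Nothing available explains why the octyl chain gives the lower number, so the result stands as an observation only.

Among these compounds, with only three compounds, it remains open whether octyl is close to the best length or merely one good point on a curve, which a butyl chain or a decyl chain would help to settle. On these data alone, it is also open whether a chain is needed here at all, or whether a different kind of group in the same place, such as an amine or a carboxylic acid, could take its role.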